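The source may report more compounds than this note shows. Statements on the series, on what has been measured and on what is new or still open speak of the compounds shown alone.

Of the compounds shown here, three sharing one core have been measured in a physicochemical assay for solubility, read by HPLC, with a stated time of 24 h; a higher number here means a more soluble compound, a lower number a less soluble compound. Compound 1 `O=C1O[C@@H](CN2CCC(c3ccc(F)cc3)CC2)CN1c1ccc(-n2cc(-c3ccccn3)cn2)c(F)c1` gives only a limit of the assay, <= 19400 nM, and the limit of <= 19400 nM in this assay, at which 1 of the 3 values shown sits, marks that boundary. Compound 2 `O=C1CNC(=O)N1C[C@H]1CN(c2ccc(-n3cc(-c4ccccn4)cn3)c(F)c2)C(=O)O1` gives 1630000 nM. Going by the values given here, compound 3 `COC[C@H]1CN(c2ccc(-n3cc(-c4ccccn4)cn3)c(F)c2)C(=O)O1` gives 36200 nM, the lowest of the two real numbers, with compound 2 as its nearest neighbour: the single step of a 45-fold lower number from compound 2 to compound 3 (1.65 log units; beyond the scatter) shows that removing the 2,5-dioxoimidazolidin-1-yl group for a methoxy on the side chain cut solubility sharply.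

Compound 4 `CONC(=O)[C@H]1CN(c2ccc(-n3cc(-c4ccccn4)cn3)c(F)c2)C(=O)O1` differs from compound 3 by methoxycarbamoyl in place of methoxymethyl on a saturated ring carbon. The entering methoxycarbamoyl brings a hydrogen-bond donor and a second acceptor where the methoxymethyl had none and one. Among the compounds with values here, the only step that bears on this is the one from compound 2 to compound 3, in which a group rich in donors and acceptors sat on the more soluble compound; that step was large. The present change is smaller in heavy atoms and lacks a ring, so the expected movement is in the same direction but of lesser size, a 4.1-fold higher number from compound 3 to compound 4 (0.62 log units; beyond the scatter), a step beyond the scatter. Compound 4 is therefore estimated at 150000 nM, within a range from 50000 nM to 450000 nM.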

Compound 4, solubility: 78100 nM
For compound 4 the middle estimate is 1.9-fold (0.28 log units) above the measured one; the range from low to high includes it.
By their numbers in this assay, from the lowest: compound 3; then compound 4; then compound 2. At a limit, below all of these: compound 1.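

At this saturated ring carbon, next to the ring oxygen, replacing methoxymethyl with methoxycarbamoyl adds a hydrogen-bond donor and gives in this assay a 2.2-fold higher number from compound 3 to compound 4 (0.33 log units; beyond the scatter) as a modest step, so a change with no ring in either group still moves the number beyond the scatter. The position also gives a 21-fold lower number from compound 2 to compound 4 (1.32 log units; beyond the scatter) as a large step, which leaves compound 4 far nearer to compound 3 than to compound 2, and the entering methoxycarbamoyl does not approach the number held by the compound with the (2,5-dioxoimidazolidin-1-yl)methyl group. No measurement shown here accounts for either step, and the limit reached by compound 1 does not bear on them.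

The compounds shown leave open whether the step goes with the amide hydrogen or with the methoxy end of methoxycarbamoyl, a question that a plain carboxamide or a methyl amide at this ring carbon would address. They also leave open how a carboxylic acid, an amine or a longer chain ending in a hydroxyl group would compare at the same place on the shared core.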